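The compounds below may be only part of what the source reports. "The series", "measured", "known", "first", "only" and "open" are said of these compounds alone.

Among the measured compounds shown here, in an ADME assay on microsomes from liver (Homo sapiens) for metabolic stability (on this read-out lower numbers stand for slow clearance and higher numbers for fast clearance), compound 1 (`CC(=O)N[C@@H]1CCC[C@H](C(=O)Nc2cc(-c3cnc4n3CCC4)c(Cl)cn2)C1`) gives 9.7 mL.min-1.g-1 and so holds the lower of the two numbers measured so far. The other belongs to compound 2 (`CC(=O)N[C@@H]1CCC[C@H](C(=O)Nc2cc(-c3cnn4c3CC(C)(C)CC4)ccn2)C1`), which gives 29 mL.min-1.g-1 as a clearly higher number, beyond the usual scatter of repeated measurements. Compound 3 (`CC(=O)N[C@@H]1CCC[C@H](C(=O)Nc2cc(-c3cnn4c3CC(C)(C)C4)c(Cl)cn2)C1`) keeps the rest of compound 1 and alters one group: a group of 10 heavy atoms (8 carbon, 2 nitrogen; one five-membered non-aromatic ring with 1 hetero atom, one five-membered aromatic ring with 2 hetero atoms) in place of a group of 8 heavy atoms (6 carbon, 2 nitrogen; one five-membered non-aromatic ring with 1 hetero atom, one five-membered aromatic ring with 2 hetero atoms), on an aromatic carbon. This group sits on an aromatic carbon, ortho to a chloro group and opposite the ring nitrogen. For the measured compounds named here, no measured pair shows this change alone, so any forecast is rough. With only compound 2 at 29 mL.min-1.g-1 as a guide, a modest rise is expected, close to the edge of the scatter, as the estimated step of a 1.9-fold higher number from compound 1 to compound 3 (0.27 log units; within the scatter) indicates. For compound 3 the estimated value is 18 mL.min-1.g-1 (expected range 8 mL.min-1.g-1 to 38 mL.min-1.g-1).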

Compound 3, intrinsic clearance in microsomes: 50 mL.min-1.g-1
Estimate against measurement, compound 3: 2.8-fold (0.44 log units) below; measured number outside the range, above it.
By their numbers in this assay, from the lowest: compound 1; then compounds 2 and 3 (each within the scatter of the next).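

Among the compounds shown here, this pair is the first to isolate a change at this position, on an aromatic carbon ortho to a chloro group and opposite the ring nitrogen. In this assay placing the group of 10 heavy atoms where the group of 8 heavy atoms stood gives a 5.2-fold higher number from compound 1 to compound 3 (0.71 log units; beyond the scatter) and so shows that the read-out responds to the group held here. This happens even though both groups have the same count of hydrogen-bond donors and acceptors and no net charge. Nothing available explains the rise.

Still open, on these data alone, is how the number would move with a quite different group at this position, such as a morpholine or a simple phenyl ring. It is also unknown whether the same swap would give a similar step on a core without the chloro group.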